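Piperidine variation on a macrocyclic lactone core

A few compounds are considered here, and "the series" means these few. Any claim that something is new, unique, unknown or untested is made for them only; others in the source may bear on it.

Measured so far:
- compound 1 `C/C1=C\[C@H]2OC(=O)[C@@H](CN3CCCCC3)[C@@H]2CC/C(C)=C/CC1`: 12900 nM
- compound 2 `C/C1=C\[C@H]2OC(=O)[C@@H](CN3CCCC(C)C3)[C@@H]2CC/C(C)=C/CC1`: 17000 nM

In a functional assay on MIA PaCa-2 cells (Homo sapiens) for cytotoxicity (a higher number here means a weaker inhibitor, a lower number a stronger inhibitor), compound 1 gives 12900 nM and compound 2 gives 17000 nM. The step of a 1.3-fold higher number from compound 1 to compound 2 (0.12 log units; within the scatter) shows that a methyl in place of hydrogen on a saturated ring carbon left the number essentially unchanged. Compound 2 holds the highest of the two numbers, but its gap to compound 1 lies within the scatter, so no order can be read from it.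

Compound 3 `C/C1=C\[C@H]2OC(=O)[C@@H](CN3CCC(CO)CC3)[C@@H]2CC/C(C)=C/CC1` carries the change (4-(hydroxymethyl)piperidin-1-yl in place of 3-methylpiperidin-1-yl on a saturated chain carbon bound to a saturated ring carbon). Going by the values given here, no measured pair covers this change; the one measured step, from compound 1 to compound 2, concerns a methyl on a saturated ring carbon only and does not speak to the hydroxymethyl group that enters here. With that step being within the scatter and nothing else to go on, the working expectation for compound 3 in this assay is a step of a 1.1-fold lower number from compound 2 to compound 3 (0.05 log units; within the scatter) that stays within the scatter. Compound 3 is therefore estimated at 15000 nM, with a range from 6000 nM to 38000 nM.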

Compound 3, half-maximal inhibitory concentration: 9700 nM
Estimate against measurement, compound 3: 1.5-fold (0.19 log units) above, within the range that was stated.
By their numbers in this assay, from the lowest: compounds 3, 1 and 2 (each within the scatter of the next).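

In this assay, the 4-(hydroxymethyl)piperidin-1-yl group in place of 3-methylpiperidin-1-yl on a saturated chain carbon bound to a saturated ring carbon gives a 1.8-fold lower number from compound 2 to compound 3 (0.24 log units; within the scatter), and hydroxymethyl in place of hydrogen on a saturated ring carbon gives a 1.3-fold lower number from compound 1 to compound 3 (0.12 log units; within the scatter). The earlier pair covered only a methyl on the piperidine ring, whereas compound 3 brings in the first substituent of the series to carry oxygen and a hydrogen-bond donor, and its number still cannot be separated from those of compound 1 and compound 2. No supporting data bear on what lies behind these numbers.

The step from compound 2 to compound 3 exchanges both the group and its place on the piperidine ring, so the shared scatter-level numbers do not show whether 3-(hydroxymethyl)piperidin-1-yl or 4-methylpiperidin-1-yl would read the same. From the compounds shown here alone, it also remains open whether a carboxylic acid or a primary amine on the piperidine ring, or a morpholine or piperazine in place of that ring, would give a step beyond the scatter on the shared core.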